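Removing the nitro group from compound 2

The source may report more compounds than this note shows. Statements on the series, on what has been measured and on what is new or still open speak of the compounds shown alone.

Measured so far in a functional assay on MCF7 cells (Homo sapiens) for inhibition; a higher number here means a weaker inhibitor, a lower number a stronger inhibitor:
- compound 1 `CCOC(=O)c1ccc(NC(=O)N2CC2C#N)cc1` gives 3300 nM
- compound 2 `N#CC1CN1C(=O)Nc1ccc([N+](=O)[O-])cc1` gives 3000 nM

Compound 2 holds the lower of the two numbers in this assay, but its gap to compound 1 lies within the scatter, so the two compounds cannot be told apart on these data. Among the compounds with values here, the single measured step, a 1.1-fold lower number from compound 1 to compound 2 (0.04 log units; within the scatter), exchanges one group on the aromatic carbon for another and leaves the read-out essentially unchanged.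

Compound 3 `N#CC1CN1C(=O)Nc1ccccc1` has not yet been measured in this assay. It differs from compound 2 by hydrogen in place of nitro on an aromatic carbon. Within the data shown here, no measured step removes the substituent at this position altogether; the only step that bears on the change is a 1.1-fold lower number from compound 1 to compound 2 (0.04 log units; within the scatter), which shows that two different groups on this carbon give numbers within the scatter of each other. On that basis no shift beyond the scatter is expected in either direction, with some allowance for a higher number, since nothing measured shows how the unsubstituted ring behaves. Compound 3 is therefore estimated at 4000 nM in this assay, between 1500 nM and 11000 nM. The expected step is a 1.3-fold higher number from compound 2 to compound 3 (0.12 log units; within the scatter).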

Compound 3, half-maximal inhibitory concentration: 4300 nM
Compound 3: middle estimate off by 1.1-fold (0.03 log units), on the low side, within the range that was stated.
By their numbers in this assay, from the lowest: compounds 2, 1 and 3 (each within the scatter of the next).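

In this assay this position can now be read against hydrogen itself: loss of the nitro group gives a 1.4-fold higher number from compound 2 to compound 3 (0.16 log units; within the scatter) and loss of the ethoxycarbonyl group gives a 1.3-fold higher number from compound 1 to compound 3 (0.11 log units; within the scatter) on the same aromatic carbon. The earlier pair compared only two substituents with each other, whereas compound 3 shows that neither substituent can be told apart from the bare ring on these data, so neither nitro nor ethoxycarbonyl is shown to be needed at this carbon, para to a group of 8 heavy atoms. No supporting data bear on this result.

Still open, going by these compounds, is whether the same holds for other groups at this carbon: an amine, a carboxylic acid, a chlorine atom or a longer alkyl chain could either stay within the scatter of these three compounds or move beyond it. The nitrile and the rest of the shared core are the same in compound 1, compound 2 and compound 3, so these compounds say nothing about how the read-out responds to a change there.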